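The compounds below may be only part of what the source reports. "The series", "measured", "known", "first", "only" and "open" are said of these compounds alone.

Measured compounds and their values in an in vitro functional assay on HEK285-7 cells for antagonist activity at prostaglandin D2 receptor 2 (Homo sapiens), read by BRET and beta-arrestin recruitment; a higher number here means a larger maximal response, a lower number a smaller maximal response:

compound 1, `O=C(O)Cc1sc(C(c2ccccc2)c2ccccc2)nc1-c1ccc(F)c(F)c1`: 80%
compound 2, `COc1ccc(C(c2ccccc2)c2nc(-c3ccc(Cl)cc3)c(CC(=O)O)s2)cc1`: 80%
compound 3, `Cc1cc(-c2nc(C(c3ccc(F)cc3)c3ccc(F)cc3)sc2CC(=O)O)cnc1N`: 80%

In this assay compound 1 gives 80%, and it stands level with compound 2 and compound 3 at the digits shown. The nearest of the two is compound 2, the furthest compound 3, yet neither gap reaches beyond the usual scatter of repeated measurements, so no order among the three can be read from these numbers. Among the compounds with values here, no pair of measured compounds that differ in only one place is at hand, so no measured step is available to guide an expectation.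

Compound 4, `O=C(O)Cc1sc(C(c2ccccc2)c2ccccc2)nc1-c1ccc(C(F)(F)F)cc1`, has not yet been measured. It differs from compound 1 in a single place:

4-(trifluoromethyl)phenyl in place of 3,4-difluorophenyl on an aromatic carbon

The change therefore puts a 4-(trifluoromethyl)phenyl in place of the 3,4-difluorophenyl on an aromatic carbon of the shared core, leaving the carboxymethyl group and the large group untouched. Given that compound 1 gives 80% and that compound 2 and compound 3, with other groups at several places, return the same maximal response within scatter, the expected step from compound 1 to compound 4 is no change at the digits printed from compound 1 to compound 4 (within the scatter), that is, no change beyond the scatter in this assay. Compound 4 is thus estimated to give 80%, with a range from 65% to 95%.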

Compound 4, largest response reached (reported as efficacy), in percent of the reference or control that the assay uses: 80%
Beside the measured number, compound 4's estimate shows no gap at the digits printed, and the stated range covers the measured number.
By their numbers in this assay, from the lowest: compounds 1, 2, 3 and 4 (each within the scatter of the next).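

Within the data shown here, replacing the 3,4-difluorophenyl with a 4-(trifluoromethyl)phenyl, on the aromatic carbon next to the ring nitrogen, gives no change at the digits printed from compound 1 to compound 4 (within the scatter) in this assay, and this is the first direct comparison at a single place in the shared core. It shows that this position accepts a group of 10 heavy atoms in place of one of 8, with the fluorines moved from the ring itself onto a trifluoromethyl group, without a change in maximal response beyond the scatter. No measurement at hand explains why these two groups give such similar results.

Both groups compared here are fluorine-bearing phenyl rings, and compound 2 and compound 3 differ from compound 1 in more than one place, so they cannot show what a different group at this position alone would do. As far as these compounds go, it remains open whether a group of another kind here, such as an unsubstituted phenyl, a nitrile-bearing phenyl or a small chain such as methyl, would also leave the maximal response unchanged or would finally move it.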